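Cyclopropylmethyl to tert-butyl on compound 2

The source may report more compounds than this note shows. Statements on the series, on what has been measured and on what is new or still open speak of the compounds shown alone.

Values measured in a functional assay on a cell-free system (plasma, Homo sapiens), with a stated time of 3 min (a lower number here means a stronger inhibitor, a higher number a weaker inhibitor), are as follows:
- Compound 1 `O=C(NCc1cc(Cl)ccc1-n1cnnn1)[C@@H]1C[C@@H]2C[C@@H]2N1C(=O)[C@H](O)CC1CC1` gives 1700 nM
- Compound 2 `O=C(NCc1cc(Cl)ccc1-n1cnnn1)[C@@H]1C[C@H]2C[C@H]2N1C(=O)[C@H](O)CC1CC1` gives 850 nM
- Compound 3 `O=C(NCc1cc(Cl)ccc1-n1cnnn1)[C@@H]1[C@H]2C[C@H]2CN1C(=O)[C@H](O)Cc1ccccc1` gives 1200 nM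

Compound 2 at 850 nM sits within the scatter of compounds 1 and 3. Compound 4 `CC(C)(C)[C@@H](O)C(=O)N1[C@@H]2C[C@@H]2C[C@H]1C(=O)NCc1cc(Cl)ccc1-n1cnnn1` differs from compound 2 as follows: tert-butyl in place of cyclopropylmethyl on a saturated chain carbon bound to a carbonyl carbon and an oxygen on a saturated carbon in words, tert-butyl in place of cyclopropylmethyl on a saturated chain carbon bound to a carbonyl carbon and an oxygen on a saturated carbon. Within the data shown here, the only measured step, a 2.0-fold lower number from compound 1 to compound 2 (0.30 log units; within the scatter), is purely configurational (the fact that compounds 1 and 2 differ only in the configuration as drawn) and leaves this group unchanged, so it gives no direct size for the exchange. No shift beyond the scatter is therefore expected in this assay, and the estimated step is a 1.2-fold lower number from compound 2 to compound 4 (0.08 log units; within the scatter) overall. Compound 4 is estimated at 700 nM within a range of 200 nM to 2500 nM in this assay.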

Compound 4, half-maximal inhibitory concentration: 1100 nM
For compound 4 the middle estimate is 1.6-fold (0.20 log units) below the measured one; the range from low to high includes it.
By their numbers in this assay, from the lowest: compounds 2, 4, 3 and 1 (each within the scatter of the next).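

Replacing cyclopropylmethyl with tert-butyl on a saturated chain carbon bound to a carbonyl carbon and an oxygen on a saturated carbon gives a 1.3-fold higher number from compound 2 to compound 4 (0.11 log units; within the scatter) in this assay. Among these compounds, this is the first readable step at this position, and it shows that an open-chain group with no ring can take the place of the ring-bearing group without a shift beyond the scatter. Left open is whether a carboxylic acid, an amine or a longer chain at this place would move the number beyond the scatter. No available evidence bears on the cause of this result.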